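Replacing the sulfonyl-bound nitrophenyl in a weak series

A few compounds are considered here, and "the series" means these few. Any claim that something is new, unique, unknown or untested is made for them only; others in the source may bear on it.

Compound 1, `Cc1ccc([N+](=O)[O-])cc1C(=O)N[C@H]1CCCN(Cc2cnn3ccc(C#N)cc23)C1`: > 1000 nM. Compound 2, `Cc1ccc([N+](=O)[O-])cc1CS(=O)(=O)c1nc(-c2cnn3ccc(Br)cc23)cs1`: > 1000 nM. Compound 3, `O=[N+]([O-])c1cccc(S(=O)(=O)c2nc(-c3cnn4ccc(Br)cc34)cs2)c1`: 5450 nM.

In an assay on isolated protein for inhibition of phosphatidylinositol 4,5-bisphosphate 3-kinase catalytic subunit beta isoform (Homo sapiens) (on this read-out higher numbers stand for weaker inhibition and lower numbers for stronger inhibition), compound 1 reaches only a limit, > 1000 nM, not a number. Compound 2 likewise stops at a limit in this assay, > 1000 nM. Compound 3 is the only one of the three with a measured number in this assay, 5450 nM, so it stands as the sole fixed point among the three, with the other two recorded at the limit of > 1000 nM in this assay, at which 2 of the 3 values shown sit.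

Compound 4, `N#Cc1cc(S(=O)(=O)c2nc(-c3cnn4ccc(Br)cc34)cs2)ccc1F`, has not yet been measured. It differs from compound 3 in a single place: 3-cyano-4-fluorophenyl in place of 3-nitrophenyl on a sulfonyl sulfur. Among the compounds with values here, no pair of measured compounds here differs in just one place, so there is no measured step to set the size of this change, and the two limits give no direction either. The expectation is therefore a step in this assay of no more than the usual scatter, in either direction, with the number for compound 4 most likely remaining weak. The estimate for compound 4 in this assay is 5000 nM, with a range from 1500 nM to 16000 nM. That estimate corresponds to an expected step of a 1.1-fold lower number from compound 3 to compound 4 (0.04 log units; within the scatter).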

Compound 4, half-maximal inhibitory concentration: > 1000 nM
Compound 4 ended at the assay's limit; the forecaster's own chance of this, stated with the estimate: 40%; the middle value is on the limit's open side.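

In this assay compound 4 gives > 1000 nM, which is a limit and not a number. Within the data shown here, no step from compound 3 to compound 4 can therefore be read. The compounds shown leave open whether 3-cyano-4-fluorophenyl in place of 3-nitrophenyl on a sulfonyl sulfur changes the number at all, or in which direction, because most values are limits: the limit of > 1000 nM in this assay, at which 3 of the 4 values shown sit.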